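The source may hold more compounds than are shown below. What is called first, only, known or untested is meant among the compounds shown, and "the series" means these compounds.

Compound 1 (`CCC[C@@H](OC(C)=O)C1=C(Br)/C(=C/Br)OC1=O`) and compound 2 (`CCC[C@@H](O)C1=C(Br)/C(=C/I)OC1=O`) share a core and were both tested in a functional assay on LNCaP cells (Homo sapiens) for cytotoxicity; on this read-out higher numbers stand for an effect only at larger amounts of compound and lower numbers for an effect already at smaller amounts. In this assay compound 1 gives 0.5 ug/mL. For compound 2 the assay reports only a limit, < 0.1 ug/mL, and the limit of < 0.1 ug/mL in this assay, at which 1 of the 2 values shown sits, marks where that value sits. Compound 3 (`CCC[C@@H](OC(C)=O)C1=C(Br)/C(=C/I)OC1=O`) has not yet been measured in this assay. It differs from compound 2 by acetyl in place of hydrogen on an oxygen on a saturated carbon, a change that read one bond further out is hydroxy to acetoxy. Among the compounds with values here, no step between compound 2 and compound 3 has been measured, and compound 2 itself stands only at a limit, so any expectation for this step is loose. Since compound 1 carries the acetyl group and still gives 0.5 ug/mL, the acetylated compound 3 is expected to remain active, with a step of an at least 1.5-fold higher number from compound 2 to compound 3 (0.17 log units; that floor lies within the scatter) expected to go toward weaker activity by a modest amount. Compound 3 is therefore estimated at 0.15 ug/mL, in a range from 0.04 ug/mL to 0.6 ug/mL.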

Compound 3, concentration for half-maximal effect: 2 ug/mL
Estimate against measurement, compound 3: 13-fold (1.12 log units) below; measured number outside the range, above it.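

In this assay, the change from hydroxy to acetoxy on the saturated carbon gives an at least 20-fold higher number from compound 2 to compound 3 (1.30 log units; beyond the scatter), so at this position the free hydroxy and the acetoxy group are far from interchangeable. Compound 2 stands only at a limit: the limit of < 0.1 ug/mL in this assay, at which 1 of the 3 values shown sits. With the acetoxy group kept in place, iodo in place of bromo on the double-bonded chain carbon bound to a double-bonded ring carbon gives a 4.0-fold higher number from compound 1 to compound 3 (0.60 log units; beyond the scatter), a modest step showing that this halogen position also moves the read-out.

The compounds shown leave open whether the same acetyl step holds when bromo sits at that chain carbon, as the pair with the free hydroxy is available only for iodo. They also leave open how an amine in place of the hydroxy, or a longer acyl chain such as butyryl on that oxygen, would read.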